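The source may report more compounds than this note shows. Statements on the series, on what has been measured and on what is new or still open speak of the compounds shown alone.

Of the compounds shown here, three that share one core have been measured in a functional assay on PC-3 cells (Homo sapiens) for inhibition, read by sulforhodamine B assay, with a stated time of 48 h; on this read-out higher numbers stand for weaker inhibition of growth and lower numbers for stronger inhibition of growth. Compound 1 `Nc1cc(N)c2nc(-c3ccccc3)c(Oc3ccc(Cl)c(Cl)c3)nc2c1` gives 3020 nM in this assay. Compound 2 `Nc1cc(N)c2nc(-c3ccccc3)c(NCc3ccc(Cl)c(Cl)c3)nc2c1` gives 1740 nM, and compound 3 `CCOC(=O)[C@H](CCC(=O)O)NC(=O)c1ccc(Oc2nc3cc(N)cc(N)c3nc2-c2ccccc2)cc1` gives 2190 nM. Compound 1 carries the highest of the three numbers, but its gap to compound 3 and its gap to compound 2 both lie within the scatter of repeated measurements, so on this read-out the three compounds look about the same and none can be called stronger or weaker than the others.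

Compound 4 `COc1ccc(Sc2nc3cc(N)cc(N)c3nc2-c2ccccc2)cc1` has not yet been measured in this assay. It differs from compound 1 in one place: (4-methoxyphenyl)sulfanyl in place of 3,4-dichlorophenoxy on an aromatic carbon.

For the measured compounds named here, no two measured compounds differ from each other in only one place, so there is no measured step to show what a change of this kind does here. What is known is that the three measured compounds, each with its own group on the shared core, give numbers within the scatter of one another, as compound 1 at 3020 nM, compound 2 at 1740 nM and compound 3 at 2190 nM show. On that basis the step of a 1.2-fold lower number from compound 1 to compound 4 (0.08 log units; within the scatter) is expected to be small, with no clear direction and possibly none beyond the scatter. Compound 4 is estimated to give 2500 nM in this assay, with a range from 800 nM to 8000 nM.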

Compound 4, concentration for 50% growth inhibition: 1740 nM
Compound 4: middle estimate off by 1.4-fold (0.16 log units), on the high side; measured number inside the range.
By their numbers in this assay, from the lowest: compounds 2, 4, 3 and 1 (each within the scatter of the next).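

In this assay, for the compounds shown here, putting (4-methoxyphenyl)sulfanyl in place of 3,4-dichlorophenoxy on the aromatic carbon next to the ring nitrogen gives a 1.7-fold lower number from compound 1 to compound 4 (0.24 log units; within the scatter), the first direct one-place comparison at this position. It shows that this particular exchange, which alters both the atom linking the aryl ring to the core and the substituents on that ring while keeping one six-membered aromatic ring and the same heavy-atom count, produces no change that can be told from the scatter. No measurement bearing on why this is so is available, so the result stands without an explanation.

From the compounds shown here alone, because the linking atom and the ring substituents change together, the effect of each alone remains unknown, and separating them would take a pair such as 4-methoxyphenoxy and (3,4-dichlorophenyl)sulfanyl on the same core. Going by these compounds, it also remains open whether a group without an aromatic ring at this position, such as morpholine or a short alkyl chain, would move the number beyond the scatter.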